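Cytotoxicity of a pyrimidinone series with small alkyl variations

This account rests on a few compounds, and the source may have more. Where it says the series, first, only, none or still open, it means among the compounds named here.

The study compares three measured compounds and one still awaiting measurement. Compound 1 has the structure `Cc1c(Cc2c(F)cccc2Cl)nc(SCC(=O)c2ccccc2)[nH]c1=O`, compound 2 the structure `CCc1c(Cc2c(F)cccc2Cl)nc(SCC(=O)c2ccccc2)[nH]c1=O`, compound 3 the structure `CC(C)c1c(Cc2c(F)cccc2Cl)nc(SCC(=O)c2ccc(F)cc2)[nH]c1=O`, and compound 4 the structure `CCC(C)c1c(Cc2c(F)cccc2Cl)nc(SCC(=O)c2ccc(F)cc2)[nH]c1=O`.

In an ADME assay on MT4 cells (Homo sapiens) for cytotoxicity, read by MTT assay (a lower number here means that less compound is tolerated, a higher number that more compound is tolerated), compound 1 gives only a limit of the assay, > 12000 nM. Compound 2 likewise gives only a limit, > 12000 nM. Compound 3 gives only a limit as well, > 56000 nM.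

The change from compound 1 to compound 2 is methyl in place of hydrogen on a saturated chain carbon bound to an aromatic carbon, and its size is a step that the two limits leave unreadable from compound 1 to compound 2, since both values sit at the limit of > 12000 nM in this assay, at which 2 of the 3 values shown sit. The difference between the core of compound 1 and the core of compound 3 is not broken down here. For the measured compounds named here, the change from compound 3 to compound 4 is methyl in place of hydrogen on a saturated chain carbon, two bonds along the chain from an aromatic carbon; it is the same kind of change as the one from compound 1 to compound 2, but the place differs, being two bonds along the chain from an aromatic carbon rather than bound to an aromatic carbon.

For compound 4 in this assay, the expected step is a step that the limit leaves unreadable from compound 3 to compound 4, resting on compound 3 sitting at the limit of > 56000 nM in this assay, at which 1 of the 3 values shown sits, and on the earlier change of the same kind leaving both values at a limit. The value expected for compound 4 is therefore 60000 nM, within a range from 20000 nM to 150000 nM.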

Compound 4, half-maximal cytotoxic concentration: > 54000 nM
Compound 4 gave a limit, no number; the forecaster's own chance of this, stated with the estimate: 80%; the middle value lies beyond the limit too.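

For the compounds shown here, compound 3 and compound 4 both give only a limit of the assay, and no size can be read for the step between them, so the methyl in place of hydrogen adds no new readable step. The compounds shown leave open at what concentration any of the four becomes toxic to the cells, and whether either methyl change alters that concentration at all.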